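Swapping the Ring on the Amide Nitrogen of Compound 1

This account rests on a few compounds, and the source may have more. Where it says the series, first, only, none or still open, it means among the compounds named here.

Among the measured compounds shown here, compound 1 `O=C(NCCCCc1ccccc1)c1cccc(C2SCC(=O)N2c2cccc(-c3c[nH]nn3)c2)c1` is the stronger of the two compounds measured so far. In a functional assay on HOS-TE85 cells (Homo sapiens) for inhibition, read by CCK-8 assay, with a stated time of 72 h (a higher number here means a weaker inhibitor, a lower number a stronger inhibitor), compound 1 gives 110 nM, whereas compound 2 `CCOC(=O)c1sc(N2C(=O)CSC2c2cccc(C(=O)NCCCCn3cccn3)c2)nc1C` gives 430 nM, a gap beyond the usual scatter. Compound 3 `COc1cccc(OC)c1N1C(=O)CSC1c1cccc(C(=O)NCCCCc2ccccc2)c1` has not yet been measured. It differs from compound 1 in one place: a group of 10 heavy atoms (8 carbon, 2 oxygen; one six-membered aromatic ring of carbon only) in place of a group of 11 heavy atoms (8 carbon, 3 nitrogen; one five-membered aromatic ring with 3 hetero atoms, one six-membered aromatic ring of carbon only), on an amide-type nitrogen in a ring. The group that leaves carries a hydrogen-bond donor; the group that enters carries none. For the measured compounds named here, with no measured step of this kind to lean on, a modest loss of potency is expected, a 2.3-fold higher number from compound 1 to compound 3 (0.36 log units; beyond the scatter). Compound 3 is therefore estimated at 250 nM, within 80 nM to 800 nM.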

Compound 3, half-maximal inhibitory concentration: > 1000 nM
Compound 3 was reported as a limit; the forecaster's own chance of this, stated with the estimate: 5%; middle value at least 4.0-fold (0.60 log units) from the limit.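

The group on this amide-type nitrogen clearly matters: with 2,6-dimethoxyphenyl in place of the group of compound 1, the result is an at least 9.0-fold higher number from compound 1 to compound 3 (0.95 log units; beyond the scatter). In this assay compound 3 gives > 1000 nM, which is a limit of the assay and not a number. The true size of the step therefore stays open, and only its minimum is known: the limit of > 1000 nM in this assay, at which 1 of the 3 values shown sits.

This single change removes the five-membered ring and adds two methoxy groups, so the effect of each remains unseparated. A plain phenyl on the same nitrogen, or a phenyl carrying a carboxylic acid, would help to tell them apart.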